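A Change on the Amine Nitrogen With No Measured Precedent

A few compounds are considered here, and "the series" means these few. Any claim that something is new, unique, unknown or untested is made for them only; others in the source may bear on it.

Of the compounds shown here, three sharing one core have been measured in a functional assay on JAR cells (Homo sapiens) for inhibition, read by MTT assay, with a stated time of 72 h, tested at 10 uM; on this read-out higher numbers stand for more inhibition at the one concentration tested (going by the name of the read-out) and lower numbers for less inhibition. Compound 1 `CCOC(=O)C1=C(Nc2ccccc2)S/C(=C\c2ccc(O)c(O)c2)C1=O` gives 48.7%, compound 2 `CCOC(=O)C1=C(Nc2ccccc2)S/C(=C\c2ccc(C(=O)O)cc2)C1=O` gives 16.8%, and compound 3 `CCOC(=O)C1=C(Nc2ccccc2Br)S/C(=C\c2ccc[nH]2)C1=O` gives 62.7%. Compound 3 therefore stands highest of the three numbers, beyond the scatter of both others. For the measured compounds named here, the only single-point step among the measured compounds is a number 31.9 percentage points lower from compound 1 to compound 2 (beyond the scatter), and it concerns the group on the double-bonded chain carbon, not the amine nitrogen.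

Compound 4 `CCOC(=O)C1=C(Nc2ccc(CC)cc2)S/C(=C\c2ccc[nH]2)C1=O` differs from compound 3 in one place: 4-ethylphenyl in place of 2-bromophenyl on an amine nitrogen. Going by the values given here, no measured step touches the group on the amine nitrogen, so there is nothing in these data that speaks to the size or direction of this change. The expectation for compound 4 is thus wide and rests only on the level of compound 3, with an estimated step of a number 12.7 percentage points lower from compound 3 to compound 4 (beyond the scatter). In this assay compound 4 is expected to give about 50%, in a range from 25% to 75%.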

Compound 4, a percentage reported as inhibition, at one concentration (the size of the read-out at that concentration, not a potency): < 10%
Compound 4: a limit, no number; the forecaster's own chance of this, stated with the estimate: 0%; middle value at least 40 percentage points from the limit.
By their numbers in this assay, from the lowest: compound 2; then compound 1; then compound 3. At a limit, below all of these: compound 4.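

For the compounds shown here, the first measured change on the amine nitrogen shows that this position is far from indifferent in this assay: 4-ethylphenyl in place of 2-bromophenyl gives a number at least 52.7 percentage points lower from compound 3 to compound 4 (beyond the scatter), whereas the only earlier step concerned the double-bonded chain carbon. Compound 4 gives < 10%, which is a limit of the assay and not a number: the limit of < 10% in this assay, at which 1 of the 4 values shown sits. As far as these compounds go, the true size of the step therefore stays unknown, and only its direction and its lower bound can be read.

The compounds shown leave open whether the loss follows the departure of bromine, the arrival of ethyl or the move from the 2-position name to the 4-position name, since both change in this one step. A 2-ethylphenyl or 4-bromophenyl group on the amine nitrogen would separate these, and a 4-methoxyphenyl group would test whether other groups named at that position behave as 4-ethylphenyl does.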